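The source may hold more compounds than are shown below. What is called first, only, known or untested is meant among the compounds shown, and "the series" means these compounds.

Measured so far: compound 1 `CN(Cc1ccc(C2=NCCN2)cc1)C(=O)COCCN(C)S(=O)(=O)c1ccccc1C#N` gives 6 in a functional assay for antagonist activity at B1 bradykinin receptor (Mus musculus), using Schild analysis, with a stated time of 30 min; a higher number here means a more potent compound, by a factor of ten per unit of this negative logarithm, a lower number a less potent compound. Compound 2 `CN(Cc1ccc(C2=NCCN2)cc1)C(=O)COCCN(C)S(=O)(=O)c1c(F)cccc1F` gives 6 in this assay.

Compound 2 stands level with compound 1; the step of no change at the digits printed from compound 1 to compound 2 (within the scatter), an exchange of the group on the sulfonyl sulfur, stayed within the scatter. Compound 3 `CN(Cc1ccc(C2=NCCN2)cc1)C(=O)COCCN(C)S(=O)(=O)c1c(Cl)cccc1Cl` differs from compound 2 by 2,6-dichlorophenyl in place of 2,6-difluorophenyl on a sulfonyl sulfur. Only no change at the digits printed from compound 1 to compound 2 (within the scatter) bears on this position, and it was flat, so no step beyond the scatter is expected in this assay. Compound 3 is therefore expected at 6, within 5.4 to 6.6. The expected step is no change at the digits printed from compound 2 to compound 3 (within the scatter), inside the scatter.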

Compound 3, negative logarithm of the antagonist equilibrium constant: 7.2
For compound 3 the middle estimate is 1.20 log units below the measured one, outside the stated range (above it).
By their numbers in this assay, from the lowest: compounds 1 and 2 (each within the scatter of the next); then compound 3.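

The group on the sulfonyl sulfur is not a silent position in this assay: 2,6-dichlorophenyl in place of 2,6-difluorophenyl gives a number 1.20 log units higher from compound 2 to compound 3 (beyond the scatter), and in place of 2-cyanophenyl it gives a number 1.20 log units higher from compound 1 to compound 3 (beyond the scatter). For the compounds shown here, the flat step seen earlier therefore held for only one exchange and does not extend to this position as a whole. Nothing available explains the difference between the chlorine and fluorine pairs.

Open, from the compounds shown here alone, is whether both chlorines are needed, which 2-chlorophenyl would address. Also open, going by these compounds, is whether 2,6-dimethylphenyl or 2,6-dibromophenyl on the sulfonyl sulfur would hold the higher number.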